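The source may hold more compounds than are shown below. What is called first, only, known or untested is meant among the compounds shown, and "the series" means these compounds.

In an ADME assay on Vero cells (Chlorocebus sabaeus) for cytotoxicity, read by MTT assay, with a stated time of 72 h (a higher number here means that more compound is tolerated, a lower number that less compound is tolerated), compound 1 `CCOC(=O)CCN1CCN(c2c(F)cc3c(=O)c(C(=O)O)cn(C4CC4)c3c2OC)CC1C` has the entry "not determined" (no result reported), so it offers no number for comparison. That leaves two measured compounds. Compound 2 `COc1c(N2CCN(C/C(C)=N/Nc3ccccc3)C(C)C2)c(F)cc2c(=O)c(C(=O)O)cn(C3CC3)c12` gives 11.1 ug/mL, and compound 3 `COc1c(N2CCN(CC/C(C)=N/O)C(C)C2)c(F)cc2c(=O)c(C(=O)O)cn(C3CC3)c12` gives 44.2 ug/mL, the higher of the two numbers and therefore the better tolerated in this assay. The gap between them lies beyond the usual scatter.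

The next compound, compound 4 `COc1c(N2CCN(CC/C(C)=N/Nc3ccccc3)C(C)C2)c(F)cc2c(=O)c(C(=O)O)cn(C3CC3)c12`, is reached from compound 3 by a single change: anilino in place of hydroxy on a double-bonded nitrogen. Put simply, this is anilino in place of hydroxy on a double-bonded nitrogen.

Among the compounds with values here, only one measured step bears on this change, namely a 4.0-fold higher number from compound 2 to compound 3 (0.60 log units; beyond the scatter). It is a modest step, and it runs from a group holding a six-membered aromatic ring to one with no ring. The new change goes the opposite way, since an aromatic ring enters, so a lower number is expected. The earlier step is not the same exchange, however, and it is the only one available, so it serves as a rough guide alone. The expected change is a 3.7-fold lower number from compound 3 to compound 4 (0.57 log units; beyond the scatter), of similar size to that step. For compound 4 the estimated value is 12 ug/mL, with an expected range of 6 ug/mL to 25 ug/mL.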

Compound 4, half-maximal cytotoxic concentration: 62.5 ug/mL
The estimate for compound 4 lay 5.2-fold (0.72 log units) below the measured number, outside the stated range (above it).
By their numbers in this assay, from the lowest: compound 2; then compounds 3 and 4 (each within the scatter of the next).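

In this assay, the exchange of hydroxy for anilino on the double-bonded nitrogen gives a 1.4-fold higher number from compound 3 to compound 4 (0.15 log units; within the scatter) and so stays within the scatter, which shows that an aromatic ring entering at this place does not by itself separate these two compounds, something the earlier step could not show because it altered the whole group at once. With a six-membered aromatic ring present on both sides, the group of 11 heavy atoms in place of the group of 10 heavy atoms gives a 5.6-fold higher number from compound 2 to compound 4 (0.75 log units; beyond the scatter) in this assay, so among these compounds the low number of compound 2 cannot be read as following from the aromatic ring alone. Nothing measured on these compounds is at hand to explain these numbers.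

The compounds shown leave open whether methoxy or benzylamino on the double-bonded nitrogen would also stay within the scatter of hydroxy and anilino. They also leave open whether a longer chain on the ring amine nitrogen, or a chloro substituent on the anilino ring, would move the number further in this assay at all.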